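This account rests on a few compounds, and the source may have more. Where it says the series, first, only, none or still open, it means among the compounds named here.

Among the compounds with values here, compound 3, `COc1ccccc1Cc1cnc(CCc2ccc(-c3ccccc3C(=O)O)cc2)[nH]1`, stands second highest of the three numbers measured so far in an in vitro functional assay on cells for agonist activity at Bombesin receptor subtype-3 (Mus musculus), read by luminescence and calcium flux; on this read-out lower numbers stand for an effect already at smaller amounts and higher numbers for an effect only at larger amounts of compound; compound 3 gives 163 nM. Its nearest neighbour is compound 1, `CCCCc1cnc(CCc2ccc(-c3ccccc3C(=O)O)cc2)[nH]1`, which in this assay gives 93 nM, and the change was a 1.8-fold higher number from compound 1 to compound 3 (0.24 log units; within the scatter). Furthest from compound 3 is compound 2, `N#Cc1ccccc1Cc1cnc(CCc2ccc(-c3ccccc3C(=O)O)cc2)[nH]1`, which gives 642 nM; that pair showed a 3.9-fold lower number from compound 2 to compound 3 (0.60 log units; beyond the scatter), while from the propyl compound the change was a 6.9-fold higher number from compound 1 to compound 2 (0.84 log units; beyond the scatter).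

The step now followed leads to compound 4, `N#Cc1cccc(Cc2cnc(CCc3ccc(-c4ccccc4C(=O)O)cc3)[nH]2)c1`, which has not yet been measured in this assay. The difference is 3-cyanophenyl in place of 2-methoxyphenyl on a saturated chain carbon bound to an aromatic carbon. Within the data shown here, only one measured step bears directly on it: the replacement of cyano by methoxy on an aromatic carbon, a 3.9-fold lower number from compound 2 to compound 3 (0.60 log units; beyond the scatter), which went beyond the scatter. Compound 4 brings a cyano group back, though as 3-cyanophenyl rather than the 2-cyanophenyl of compound 2, so the earlier step is a guide of limited reliability. A modest rise in the number is therefore expected, smaller than a plain reversal, with the step estimated at a 2.3-fold higher number from compound 3 to compound 4 (0.37 log units; beyond the scatter). For compound 4 the value in this assay is estimated at 380 nM, with a range from 150 nM to 1100 nM.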

Compound 4, half-maximal effective concentration: 20 nM
Estimate against measurement, compound 4: 19-fold (1.28 log units) above; measured number outside the range, below it.
By their numbers in this assay, from the lowest: compound 4; then compounds 1 and 3 (each within the scatter of the next); then compound 2.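

The two cyano compounds show that at this position the number depends on more than the presence of a nitrile: in this assay the 3-cyanophenyl group in place of 2-cyanophenyl gives a 32-fold lower number from compound 2 to compound 4 (1.51 log units; beyond the scatter). Nitrile against methoxy therefore no longer reads in one direction, since 3-cyanophenyl in place of 2-methoxyphenyl gives an 8.2-fold lower number from compound 3 to compound 4 (0.91 log units; beyond the scatter), the opposite direction to the earlier methoxy-for-cyano step, and an aryl group at this place is also no longer confined to matching or exceeding the propyl compound, with a 4.7-fold lower number from compound 1 to compound 4 (0.67 log units; beyond the scatter). Nothing available here accounts for this difference between the two cyanophenyl groups.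

The step from compound 3 to compound 4 alters both the group and the way it is attached to the phenyl ring, so the compounds shown cannot divide it into a part belonging to the nitrile and a part belonging to its placing. They also leave open whether an amine or an ethyl group carried on the phenyl ring in the same way as the nitrile of compound 4 would give a similarly low number, or whether that result is particular to the nitrile.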